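Ethyl for Trifluoromethyl on a Tetralone-Derived Inhibitor

A few compounds are considered here, and "the series" means these few. Any claim that something is new, unique, unknown or untested is made for them only; others in the source may bear on it.

Compounds measured so far:
Compound 1, `COc1ccc2c(c1)CC/C(=C\c1ccccc1C)C2=O`: 480000 nM
Compound 2, `COc1ccc2c(c1)CCC(Cc1ccccc1C(F)(F)F)C2=O`: 2080 nM

In an assay on CHO cells for inhibition of 1,25-dihydroxyvitamin D(3) 24-hydroxylase, mitochondrial (Homo sapiens) (a higher number here means a weaker inhibitor, a lower number a stronger inhibitor), compound 2 gives 2080 nM, the lower of the two numbers, and so the stronger inhibitor of the pair. In this assay compound 1 gives 480000 nM, a far higher number, and the gap between the two lies well beyond the usual scatter. The two compounds differ in more than one place, so no single step can be read from them.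

Compound 3, `CCc1ccccc1CC1CCc2cc(OC)ccc2C1=O`, has not yet been measured. It differs from compound 2 in one place: ethyl in place of trifluoromethyl on an aromatic carbon. Going by the values given here, no measured pair shows this kind of exchange here. The step from compound 2 to compound 3 is expected to be small, in either direction or not beyond the scatter; the estimate is a 1.4-fold higher number from compound 2 to compound 3 (0.16 log units; within the scatter). Compound 3 is expected to give 3000 nM, within a range from 800 nM to 12000 nM.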

Compound 3, half-maximal inhibitory concentration: 1920 nM
Beside the measured number, compound 3's estimate is 1.6-fold (0.19 log units) above it; the range from low to high includes it.
By their numbers in this assay, from the lowest: compounds 3 and 2 (each within the scatter of the next); then compound 1.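

In this assay the exchange of trifluoromethyl for ethyl on this aromatic carbon, ortho to a large group, gives a 1.1-fold lower number from compound 2 to compound 3 (0.03 log units; within the scatter) and leaves compound 2 and compound 3 indistinguishable. Going by these compounds alone, this is the first comparison here of compounds that differ in only one place, and it shows that this position holds either group, with four heavy atoms leaving and two entering, without a measurable difference in this assay. No measured evidence is available to explain why the two groups read alike.

From the compounds shown here alone, only these two groups can be compared at this position, so it remains open whether an amine, a carboxylic acid or a longer chain would leave the number unchanged or move it. Compound 1 differs from the others in more than one place, so the steps to it cannot be read.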